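From 4-hydroxyphenyl to 3,4-dichlorophenyl at a measuring limit

The source may report more compounds than this note shows. Statements on the series, on what has been measured and on what is new or still open speak of the compounds shown alone.

Compound 1 `CCCCCCOc1cccc(O)c1C(=O)/C=C/c1ccc(O)cc1`: > 30000 nM (a limit)
Compound 2 `CCCCCCCCOc1cccc(O)c1C(=O)/C=C/c1ccc(O)cc1`: > 30000 nM (a limit)
Compound 3 `CCCCCCCCCCOc1cccc(O)c1C(=O)/C=C/c1ccc(O)cc1`: > 30000 nM (a limit)

These readings come from an ADME assay on RAW264.7 cells (Mus musculus) for cytotoxicity, read by MTT assay (a lower number here means a stronger inhibitor, a higher number a weaker inhibitor), and none of them is an exact number. Compound 3 gives only a limit (> 30000 nM) and no measured value. The whole set rests on the limit of > 30000 nM in this assay, at which 3 of the 3 values shown sit, and no order can be drawn among the three compounds.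

Compound 4 `CCCCCCCCCCOc1cccc(O)c1C(=O)/C=C/c1ccc(Cl)c(Cl)c1` differs from compound 3 in one place (3,4-dichlorophenyl in place of 4-hydroxyphenyl on a double-bonded chain carbon bound to a double-bonded chain carbon): 3,4-dichlorophenyl stands in place of 4-hydroxyphenyl on a double-bonded chain carbon bound to a double-bonded chain carbon.

Three measured steps are available: a step that the two limits leave unreadable from compound 1 to compound 2 and a step that the two limits leave unreadable from compound 1 to compound 3 and a step that the two limits leave unreadable from compound 2 to compound 3 all concern the saturated chain, not the group that changes here. None has a readable size, so they give neither a size nor a direction to carry over to this change. Expected is a number no higher from compound 3 to compound 4 (the limit leaves the size open) with no direction that these steps could settle. A further limit in place of a number is the likeliest result. The estimate for compound 4 is 30000 nM (expected range 10000 nM to 60000 nM).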

Compound 4, half-maximal inhibitory concentration: > 30000 nM
Compound 4 gave a limit, no number (the forecaster's own chance of this, stated with the estimate: 70%); the middle value lies on the limit itself.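

Compound 3 and compound 4 each give only a limit, so no new step can be read from compound 3 to compound 4, neither a size nor a direction: the limit of > 30000 nM in this assay, at which 4 of the 4 values shown sit.

The compounds shown leave open where the true value of each lies, and whether changing the chain or putting 3,4-dichlorophenyl in place of 4-hydroxyphenyl alters cytotoxicity at all.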